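Serine in place of methionine on a purine glycine amide

The compounds below may be only part of what the source reports. "The series", "measured", "known", "first", "only" and "open" are said of these compounds alone.

Compounds measured so far:
- compound 1, `O=C(O)[C@@H]1CCCN1C(=O)CN(c1nc(Cl)nc2[nH]cnc12)C1CC1`, gives 26%
- compound 2, `NC(=O)CC[C@H](NC(=O)CN(c1nc(Cl)nc2[nH]cnc12)C1CC1)C(=O)O`, gives 41.1%
- compound 3, `CSCC[C@H](NC(=O)CN(c1nc(Cl)nc2[nH]cnc12)C1CC1)C(=O)O`, gives 14%

These three share a core and differ in the amino acid joined to the glycine amide. In a functional assay on the whole organism (Tail, strain ICR) with Mus musculus as the target, in the tail flick test, with a stated time of 90 min, at a dose of 25 umol/kg by the oral route (on this read-out lower numbers stand for a weaker effect and higher numbers for a stronger effect at the one dose given), compound 2 gives 41.1%, while compound 1 gives 26% and compound 3 gives 14%. Compound 3 stands lowest of the three; its nearest neighbour is compound 1, and both of its gaps lie beyond the scatter. For the measured compounds named here, the one measured step that reaches compound 3 is a number 27.1 percentage points lower from compound 2 to compound 3 (beyond the scatter).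

Compound 4, `O=C(CN(c1nc(Cl)nc2[nH]cnc12)C1CC1)N[C@@H](CO)C(=O)O`, is the next in line. It differs from compound 3 in one place: hydroxy in place of (methylsulfanyl)methyl on a saturated chain carbon, two bonds along the chain from an amide-type nitrogen and a carbonyl carbon. Going by the values given here, no pair so far tells exactly this change, but the step from compound 2 to compound 3 bears on it, since that step exchanged a group carrying a hydrogen-bond donor for one carrying none and lowered the read-out by a modest amount. Compound 4 brings a donor back in, so a rise is expected, though of uncertain size. The step expected from compound 3 to compound 4 is a number 16 percentage points higher from compound 3 to compound 4 (beyond the scatter). Compound 4 is therefore estimated at 30%, within a range from 12% to 50%.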

Compound 4, a percentage reported as activity, at one dose (the size of the read-out at that dose, not a potency): 43.9%
Beside the measured number, compound 4's estimate is 13.9 percentage points below it; the range from low to high includes it.
By their numbers in this assay, from the lowest: compound 3; then compound 1; then compounds 2 and 4 (each within the scatter of the next).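

In this assay, hydroxy in place of (methylsulfanyl)methyl gives a number 29.9 percentage points higher from compound 3 to compound 4 (beyond the scatter), so a group of only one heavy atom at this position more than makes up the loss seen earlier with the methylsulfanyl chain. The chain also proves not to need its length for this level of effect: hydroxy in place of carbamoylmethyl gives a number 2.8 percentage points higher from compound 2 to compound 4 (within the scatter), which leaves the short group and the longer amide-bearing chain indistinguishable at this dose. The open-chain compound also compares well with the ring-closed one, since (1-carboxy-2-hydroxyethyl)amino in place of 2-carboxypyrrolidin-1-yl gives a number 17.9 percentage points higher from compound 1 to compound 4 (beyond the scatter).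

The compounds shown do not separate the effect of the hydroxy itself from that of the shorter chain, a question that a methyl, a methoxy, an amine or a longer chain ending in hydroxy at this position could address. Nothing available here accounts for why the read-out changes with these groups.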